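Closing the Amine Tail of Compound 1 into a Ring

A few compounds are considered here, and "the series" means these few. Any claim that something is new, unique, unknown or untested is made for them only; others in the source may bear on it.

Compound 1, `COc1ccc(F)c(-c2ccc3c(NC(=O)c4ccc(N(C)CCN(C)C)cc4)n[nH]c3c2)c1F`: 366 nM
Compound 3, `CCN1CCN(c2ccc(C(=O)Nc3n[nH]c4cc(-c5c(F)ccc(OC)c5F)ccc34)cc2)CC1`: 77.4 nM
Compound 2, `CCN1CCN(c2ccc(C(=O)Nc3n[nH]c4cc(-c5cccc(OC)c5F)cc(F)c34)cc2)CC1`: > 1000 nM, a limit of the assay

In a functional assay on SNU-16 cells (Homo sapiens) for antiproliferative activity, read by CCK-8 assay, with a stated time of 72 h (on this read-out lower numbers stand for stronger inhibition and higher numbers for weaker inhibition), compound 1 gives 366 nM, the highest of the two numbers reported, with compound 3 as its nearest neighbour. The reading for compound 2 is only a limit, (the limit of > 1000 nM in this assay, at which 1 of the 3 values shown sits), and not a number.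

Compound 4, `COc1ccc(F)c(-c2ccc3c(NC(=O)c4ccc(N5CCN(C)CC5)cc4)n[nH]c3c2)c1F`, differs from compound 1 in one place: 4-methylpiperazin-1-yl in place of (2-(dimethylamino)ethyl)(methyl)amino on an aromatic carbon. Among the compounds with values here, the one measured step that bears on this is a 4.7-fold lower number from compound 1 to compound 3 (0.67 log units; beyond the scatter), where a closely related ring tail, 4-ethylpiperazin-1-yl, replaced the same open chain. A step of the same direction and roughly the same size is therefore expected. Compound 4 is estimated to give 100 nM, within 40 nM to 300 nM, an expected step of a 3.7-fold lower number from compound 1 to compound 4 (0.56 log units; beyond the scatter).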

Compound 4, half-maximal inhibitory concentration: 35.6 nM
Beside the measured number, compound 4's estimate is 2.8-fold (0.45 log units) above it; the measured number lies below the stated range.
By their numbers in this assay, from the lowest: compound 4; then compound 3; then compound 1. At a limit, above all of these: compound 2.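

In this assay, closing the open chain into a ring goes further with 4-methylpiperazin-1-yl than the ethyl ring had shown, giving a 10-fold lower number from compound 1 to compound 4 (1.01 log units; beyond the scatter). Even the small change from 4-ethylpiperazin-1-yl to 4-methylpiperazin-1-yl registers, with a 2.2-fold lower number from compound 3 to compound 4 (0.34 log units; beyond the scatter), so the size of the alkyl group on this ring matters in this series. Nothing measured here gives a cause for either step. Still open, on these data alone, is how the reading would shift with a plain piperazine carrying hydrogen in place of the methyl, or with a morpholine ring in place of the piperazine.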